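The compounds below may be only part of what the source reports. "The series", "measured", "known", "first", "only" and "open" are said of these compounds alone.

Measured compounds:
- compound 1, `c1ccc2c(c1)CCCCC2CCN1CCN(c2cccc3c2OCCO3)CC1`, in a functional assay on the whole organism for agonist activity, with Rattus norvegicus as the target (a lower number here means that less compound is needed, a higher number that more compound is needed for the effect), gives a limit of the assay, > 10 mg/kg.
- compound 2, `c1ccc2c(c1)CC2CCCN1CCN(c2cccc3c2OCCO3)CC1`, in this assay gives 10 mg/kg.
- compound 3, `C1=C(CCN2CCN(c3cccc4c3OCCO4)CC2)c2ccccc2C1`, in this assay gives only a limit of the assay, > 2.5 mg/kg.

Compound 3 therefore stands at a limit rather than at a number; of the three values shown, it is one of two that are limits, the other being that of compound 1 at the limit of > 10 mg/kg in this assay, at which 1 of the 3 values shown sits, while compound 3 sits at the limit of > 2.5 mg/kg in this assay, at which 1 of the 3 values shown sits. For the measured compounds named here, the only measured step that touches compound 3 is a step that the limit leaves unreadable from compound 2 to compound 3, and its size cannot be read because of the limit.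

Compound 4, `C1=C(CCN2CCN(c3cccc4c3OCCO4)CC2)Cc2ccccc21`, differs from compound 3 by a group of 9 heavy atoms (9 carbon; one five-membered non-aromatic ring of carbon only, one six-membered aromatic ring of carbon only) in place of a group of 9 heavy atoms (9 carbon; one five-membered non-aromatic ring of carbon only, one six-membered aromatic ring of carbon only), on a saturated chain carbon, two bonds along the chain from an amine nitrogen in a ring. Going by the values given here, no measured step compares two groups of this kind, so the expected change is small: in this assay the step from compound 3 to compound 4 is expected to be a step that the limit leaves unreadable from compound 3 to compound 4, within the scatter. Compound 4 is thus expected to give about 5 mg/kg in this assay, with a range from 2 mg/kg to 15 mg/kg, and it may well come back only as a limit.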

Compound 4, minimum effective dose: 10 mg/kg
The estimate for compound 4 lay 2.0-fold (0.30 log units) below the measured number; the measured number falls inside the stated range.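

For the compounds shown here, compound 4 gives the first readable comparison for a group with a five-membered ring at this place, on a saturated chain carbon, two bonds along the chain from an amine nitrogen in a ring. In this assay, that group in place of the group with the four-membered ring gives no change at the digits printed from compound 2 to compound 4 (within the scatter). The steps that touch compound 3 cannot be read, because compound 3 stands only at a limit of the assay: the limit of > 2.5 mg/kg in this assay, at which 1 of the 4 values shown sits.

On these data alone, it therefore stays open whether the two differently joined groups of compound 3 and compound 4 differ at all in this assay. Also open, as far as these compounds go, is how a longer chain at this place, or a hydroxyl group on the five-membered ring, would read there.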